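Chloro on the fused ring of compound 3

The source may report more compounds than this note shows. Statements on the series, on what has been measured and on what is new or still open speak of the compounds shown alone.

Compound 1, `COc1ccccc1N1CCN(C(=O)c2nc3cc(Cl)ccc3s2)CC1`, gives 63.4%.
Compound 2, `COc1ccc(N2CCN(C(=O)c3nc4cc(Cl)ccc4s3)CC2)cc1`, gives 42.8%.
Compound 3, `O=C(c1nc2ccccc2s1)N1CCN(c2ccccc2)CC1`, gives 67.2%.

These three numbers come from an ADME assay on RAW264.7 cells (Mus musculus) for cytotoxicity, read by MTT assay, with a stated time of 72 h, tested at 50 ug/mL; a higher number here means more inhibition at the concentration tested (going by the name of the read-out), a lower number less inhibition. Compound 3 has the highest of the three values, but its nearest neighbour is compound 1, whose value lies within the scatter of it, while compound 2 lies further off, beyond the scatter. Going by the values given here, the one step between compounds that differ in a single place is a number 20.6 percentage points lower from compound 1 to compound 2 (beyond the scatter), a modest change that concerns the methoxyphenyl group on the amine nitrogen in a ring, not the fused ring system.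

Compound 4, `O=C(c1nc2cc(Cl)ccc2s1)N1CCN(c2ccccc2)CC1`, has not yet been tested in this assay. It differs from compound 3 in one place: chloro in place of hydrogen on an aromatic carbon. Among the compounds with values here, no measured step bears directly on this change, because compound 1 and compound 3 differ from each other in two places at once. What can be said is that compound 1, which carries the chloro on its fused ring, and compound 3, which does not, give values within the scatter of each other. Compound 4 is therefore expected to show a number 2.2 percentage points lower from compound 3 to compound 4 (within the scatter), a step of no consequence beyond the scatter. The estimate for compound 4 is 65%, with a range from 50% to 80%.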

Compound 4, a percentage reported as inhibition, at one concentration (the size of the read-out at that concentration, not a potency): 41.2%
The estimate for compound 4 lay 23.8 percentage points above the measured number, and the stated range ends above it.
By their numbers in this assay, from the lowest: compounds 4 and 2 (each within the scatter of the next); then compounds 1 and 3 (each within the scatter of the next).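

In this assay the change of chloro in place of hydrogen on the six-membered aromatic ring of the fused system can now be read on its own as a number 26 percentage points lower from compound 3 to compound 4 (beyond the scatter) and shows that this position is not indifferent to the group it carries, at least on the unsubstituted phenyl of compound 3. With the chloro held in place, the two methoxy groups also part ways: hydrogen in place of methoxy reads as a number 22.2 percentage points lower from compound 1 to compound 4 (beyond the scatter) for the 2-methoxyphenyl and as a number 1.6 percentage points lower from compound 2 to compound 4 (within the scatter) for the 4-methoxyphenyl, so among these compounds a methoxy group goes with a higher number only in compound 1, and compound 2 goes against any general effect of methoxy. Nothing available explains these steps.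

From the compounds shown here alone, whether fluoro, bromo, methyl or an amine in place of hydrogen on this aromatic carbon would give a step like that of chloro stays open. So does the size of the chloro step when the phenyl carries a methoxy group in place of hydrogen, and whether that step would resemble the one seen on the unsubstituted phenyl.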